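Swapping methoxy for methyl on a fused core

The compounds below may be only part of what the source reports. "The series", "measured", "known", "first", "only" and "open" are said of these compounds alone.

Of the compounds shown here, three sharing one core have been tested in an assay on isolated protein for displacement of a labelled ligand from metabotropic glutamate receptor 5 (Homo sapiens), with a stated time of 60 min, tested at 1 uM; on this read-out higher numbers stand for more inhibition at the one concentration tested (going by the name of the read-out) and lower numbers for less inhibition. Compound 1 `COc1ccc2ncc(S(=O)(=O)c3ccc(OC)c(Cl)c3)c(N3CCC(C)CC3)c2c1` gives 21%, compound 2 `COc1ccc2ncc(S(=O)(=O)c3cccc(F)c3)c(N3CCC(C)CC3)c2c1` gives 68%, and compound 3 `COc1ccc2ncc(S(=O)(=O)c3cccc(Cl)c3)c(N3CCC(C)CC3)c2c1` gives -3%. Compound 2 stands highest of the three: the nearest value is separated from it by a number 47 percentage points higher from compound 1 to compound 2 (beyond the scatter), and the furthest by a number 71 percentage points lower from compound 2 to compound 3 (beyond the scatter).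

Compound 4 `Cc1ccc2ncc(S(=O)(=O)c3cccc(F)c3)c(N3CCC(C)CC3)c2c1` is the next step, made from compound 2 by methyl in place of methoxy on an aromatic carbon. This change sits on an aromatic carbon of a six-membered aromatic ring of carbon only, part of a fused or bridged system of two rings. Among the compounds with values here, no measured step changes this position. Within the data shown here, the only step touching a methoxy is a number 24 percentage points lower from compound 1 to compound 3 (beyond the scatter), where hydrogen replaced methoxy on the other ring, a modest drop. Because a number 24 percentage points lower from compound 1 to compound 3 (beyond the scatter) concerns a different place and a different entering group, it guides only loosely, and a modest fall or no change is expected.

Compound 4 is estimated at 52%, within 22% to 80%, an expected step of a number 16 percentage points lower from compound 2 to compound 4 (beyond the scatter).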

Compound 4, a percentage reported as inhibition, at one concentration (the size of the read-out at that concentration, not a potency): 94%
Compound 4: middle estimate off by 42 percentage points, on the low side, and the stated range ends below it.
By their numbers in this assay, from the lowest: compound 3; then compound 1; then compound 2; then compound 4.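

Replacing the methoxy with methyl at this position gives a number 26 percentage points higher from compound 2 to compound 4 (beyond the scatter) in this assay. Within the data shown here, this is the first measured step at this aromatic carbon, and it shows that inhibition at the one concentration tested responds to the group placed here. It also shows, for this pair, that the methoxy's oxygen and its one hydrogen-bond acceptor are not needed for this level of inhibition, although no measurement here explains the rise.

This single pair cannot show whether a longer chain such as ethyl, or a group with a different kind of atom such as an amine, would raise or lower the number further at this position. It also leaves open whether methyl would give a similar rise on compound 1 or compound 3, which carry other groups on the sulfonyl sulfur.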